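Swapping benzyloxy for carboxy at the assay limit

The compounds below may be only part of what the source reports. "The series", "measured", "known", "first", "only" and "open" are said of these compounds alone.

Measured in a functional assay on HEL cells (Homo sapiens); on this read-out lower numbers stand for higher toxicity in this test and higher numbers for lower toxicity in this test:
- Compound 1 `C=C(C)C(=O)NC(=O)NC1=CS(=O)(=O)O[C@@]12[C@@H](CO[Si](C)(C)C(C)(C)C)O[C@@H](n1cc(C)c(=O)n(C)c1=O)[C@@H]2O[Si](C)(C)C(C)(C)C`: 1200 nM
- Compound 2 `Cc1cn([C@@H]2O[C@H](CO[Si](C)(C)C(C)(C)C)[C@@]3(OS(=O)(=O)C=C3NCC(=O)OCc3ccccc3)[C@H]2O[Si](C)(C)C(C)(C)C)c(=O)n(C)c1=O`: > 200000 nM

Compound 2 gives > 200000 nM, which is a limit of this assay and not a number. Compound 3 `Cc1cn([C@@H]2O[C@H](CO[Si](C)(C)C(C)(C)C)[C@@]3(OS(=O)(=O)C=C3NCC(=O)C(=O)O)[C@H]2O[Si](C)(C)C(C)(C)C)c(=O)n(C)c1=O` differs from compound 2 by carrying carboxy in place of benzyloxy on a carbonyl carbon, so that (benzyloxycarbonyl)methyl becomes (carboxycarbonyl)methyl on the amine nitrogen.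

Among the measured compounds shown here, only one measured step bears on this change. The large step of an at least 160-fold higher number from compound 1 to compound 2 (2.22 log units; beyond the scatter) lies beyond the scatter and shows that the group on this amine nitrogen can move the read-out strongly. However, that step replaces ((1-methylethenyl)carbonyl)carbamoyl, a group that compound 3 does not carry, and no measured step covers the new exchange itself. A large step in this assay is therefore not expected, and any modest shift should run towards lower numbers. The step expected is an at least 1.3-fold lower number from compound 2 to compound 3 (0.12 log units; that floor lies within the scatter). For compound 3 the estimated value is 150000 nM, with an expected range from 40000 nM to 300000 nM.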

Compound 3, half-maximal cytotoxic concentration: 146000 nM
The estimate for compound 3 lay 1.0-fold (0.01 log units) above the measured number; measured number inside the range.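

Compound 2 sits at a limit of this assay, which is not a number: the limit of > 200000 nM in this assay, at which 1 of the 3 values shown sits.

Carboxy in place of benzyloxy on a carbonyl carbon can therefore be read only as a smallest size, an at least 1.3-fold lower number from compound 2 to compound 3 (0.13 log units; that floor lies within the scatter), and how large the change really is stays unknown. Compound 3 does give this amine nitrogen a measured value at the high end of the read-out, and it shows a second group there standing well apart from ((1-methylethenyl)carbonyl)carbamoyl: a 120-fold higher number from compound 1 to compound 3 (2.09 log units; beyond the scatter). The large gap seen with (benzyloxycarbonyl)methyl thus does not depend on benzyloxy or its aromatic ring, as it persists with (carboxycarbonyl)methyl, which has neither.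

The compounds shown leave open whether a methyl ester or an amide in place of the carboxy group would keep the read-out this high, and whether a longer chain on the amine nitrogen would do the same. They also leave open which part of ((1-methylethenyl)carbonyl)carbamoyl goes with the low number of compound 1, for instance whether a plain acetyl in place of its (1-methylethenyl)carbonyl would give a similar value.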